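The compounds below may be only part of what the source reports. "The series", "measured", "known", "first", "only" and "open" are said of these compounds alone.

Among the measured compounds shown here, compound 1 `CCOC(=O)c1ccc(-c2nn(Cc3ccccc3Cl)c3ccccc23)cc1` is the only member of the series with a measured number: in a functional assay on cells (Platelet, Homo sapiens) for inhibition (on this read-out lower numbers stand for stronger inhibition and higher numbers for weaker inhibition), compound 1 gives 230 nM. Compound 2 `CCOC(=O)/C=C/c1ccc(-c2nn(Cc3ccccc3)c3ccccc23)cc1` is known only through (the limit of > 10000 nM in this assay, at which 1 of the 2 values shown sits); in this assay compound 2 gives > 10000 nM, which is a limit of the assay rather than a number. For the measured compounds named here, no pair of measured compounds differing in a single place is available, so the series supplies no measured size for any one structural change.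

Compound 3 `CCOC(=O)c1ccc(-c2nn(-c3ccccc3)c3ccccc23)cc1` differs from compound 1 by phenyl in place of 2-chlorobenzyl on an aromatic nitrogen. With the 2-chlorobenzyl giving way to phenyl on the aromatic nitrogen, a step toward weaker inhibition in this assay is expected, of modest size but beyond the usual scatter, although nothing measured here fixes it. The expected step is a 3.0-fold higher number from compound 1 to compound 3 (0.48 log units; beyond the scatter). Compound 3 is accordingly estimated at 700 nM, with a likely range from 200 nM to 3000 nM.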

Compound 3, half-maximal inhibitory concentration: 2640 nM
Compound 3: the middle estimate sits 3.8-fold (0.58 log units) below what was measured, within the range that was stated.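

At the aromatic nitrogen the series now has its first measured single change: in this assay phenyl in place of 2-chlorobenzyl gives an 11-fold higher number from compound 1 to compound 3 (1.06 log units; beyond the scatter) on the shared core. The position is therefore not indifferent to the group it carries, and a change here can move the read-out well beyond the scatter. The step combines the loss of the chlorine with the loss of the benzyl carbon, and nothing measured here gives a cause for it.

Open, on these data alone, is how far a plain benzyl or a longer phenethyl chain on this nitrogen, with the ethyl ester of compound 1 kept, would separate those two parts of the change. Also open, as far as these compounds go, is how a carboxylic acid or an amide would read in place of that ethyl ester.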